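The source may report more compounds than this note shows. Statements on the series, on what has been measured and on what is new or still open speak of the compounds shown alone.

Measured so far:
Compound 1, `CS(=O)(=O)c1ccc(-c2cnc3[nH]cc(-c4nnc(-c5ccncc5)o4)c(=O)c3c2)cc1`: in a functional assay on HCT-116 cells (Homo sapiens) for inhibition, read by MTT assay, with a stated time of 24 h, tested at 2.5 uM (on this read-out higher numbers stand for more inhibition of growth at the one concentration tested and lower numbers for less inhibition of growth), compound 1 gives 2.64%.
Compound 2, `CS(=O)(=O)c1ccc(-c2cnc3[nH]cc(-c4nnc(-c5ccc(F)cc5)o4)c(=O)c3c2)cc1`: in this assay compound 2 gives 10.7%.

Compound 2 holds the larger of the two numbers shown, but the single measured step, a number 8.1 percentage points higher from compound 1 to compound 2 (within the scatter), lies within the scatter, so compound 1 and compound 2 stand level. Compound 3, `CS(=O)(=O)c1ccc(-c2cnc3[nH]cc(-c4nnc(-c5ccccc5)o4)c(=O)c3c2)cc1`, differs from compound 2 by hydrogen in place of fluoro on an aromatic carbon. For the measured compounds named here, no measured step covers a replacement of this kind; the one available step concerns a different change and was itself within the scatter. No movement beyond the scatter is therefore expected in this assay, and the estimated step of a number 0.7 percentage points lower from compound 2 to compound 3 (within the scatter) stays inside it. Compound 3 is expected to give 10%, ranging from 0% to 22%.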

Compound 3, percent growth inhibition at one concentration: 0.53%
Beside the measured number, compound 3's estimate is 9.5 percentage points above it; the range from low to high includes it.
By their numbers in this assay, from the lowest: compounds 3, 1 and 2 (each within the scatter of the next, the first and the last beyond it).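

In this assay, for the compounds shown here, hydrogen in place of fluoro on the aromatic carbon para to a large group gives a number 10.2 percentage points lower from compound 2 to compound 3 (beyond the scatter) and so provides the first step beyond the scatter, though a modest one. Phenyl in place of pyridin-4-yl gives a number 2.1 percentage points lower from compound 1 to compound 3 (within the scatter) and leaves compound 1 level with compound 3, while compound 1 also stands level with compound 2. No measured property bears on these steps.

As far as these compounds go, whether chloro, methoxy or an amine on that carbon would give numbers like that of compound 2 or compound 3 stays open. From the compounds shown here alone, how these differences hold at other concentrations also stays open.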